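This account rests on a few compounds, and the source may have more. Where it says the series, first, only, none or still open, it means among the compounds named here.

The study compares four amides for their effect on cells in a toxicity assay on Huh-7.5 cells (Homo sapiens) for inhibition, read by MTT assay, with a stated time of 96 h; on this read-out higher numbers stand for lower toxicity in this test and lower numbers for higher toxicity in this test. Compound 1 `COc1ccc(C(=O)Nc2ccc(N(C)C)cc2)cc1[N+](=O)[O-]` gives 88200 nM, and compound 2 `CC(C)Oc1ccc(C(=O)Nc2ccc(N(C)C)cc2)cc1[N+](=O)[O-]` gives 50000 nM. These two differ only by methyl in place of isopropyl on an oxygen on an aromatic ring, and that change produces a 1.8-fold higher number from compound 2 to compound 1 (0.25 log units; within the scatter). Compound 3 `CCC(=O)Nc1cc(C(=O)Nc2ccc(CN3CCN(C)CC3)c(C(F)(F)F)c2)ccc1OC(C)C` gives 15300 nM in this assay, the lowest of the three numbers; the difference between its core and the core of compound 2 is not broken down here. Compound 4 `CCC(=O)Nc1cc(C(=O)Nc2ccc(CN3CCN(C)CC3)c(C(F)(F)F)c2)ccc1OC` has not yet been measured in this assay. It differs from compound 3 by methyl in place of isopropyl on an oxygen on an aromatic ring, the same change already seen from compound 2 to compound 1, at the same place. Because that earlier step was a 1.8-fold higher number from compound 2 to compound 1 (0.25 log units; within the scatter), compound 4 is expected to show a 1.4-fold higher number from compound 3 to compound 4 (0.16 log units; within the scatter), a move of similar size that stays within the scatter. On that basis the value of compound 4 in this assay is estimated at 22000 nM, with a likely range from 10000 nM to 45000 nM.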

Compound 4, half-maximal cytotoxic concentration: 35300 nM
The estimate for compound 4 lay 1.6-fold (0.21 log units) below the measured number; the measured number falls inside the stated range.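

In this assay, replacing isopropyl with methyl on the oxygen on the aromatic ring of the core of compound 3 gives a 2.3-fold higher number from compound 3 to compound 4 (0.36 log units; beyond the scatter). Set beside the earlier step on the other core, the new step cannot be told apart from it: the same change on two cores in this assay, a 1.8-fold higher number (0.25 log units; within the scatter) from compound 2 to compound 1 and a 2.3-fold higher number (0.36 log units; beyond the scatter) from compound 3 to compound 4, 1.3-fold (0.12 log units) apart, within the scatter of two such steps. This shows that, on these two cores, the change from isopropoxy to methoxy carried over at a comparable size, although only the new step lies beyond the scatter; it does not show that the change would behave alike on any further core, and two pairs cannot explain why the numbers move.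

The compounds shown leave open how an ethyl group or a longer chain ending in an amine on that same oxygen would read in this assay. They also leave open whether the step from isopropoxy to methoxy keeps its size on a core that carries a carboxylic acid.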